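The source may report more compounds than this note shows. Statements on the series, on what has been measured and on what is new or still open speak of the compounds shown alone.

- Compound 1 `O=C(/C(=C\c1ccccc1OCc1ccccc1)SCc1ccc(F)cc1)c1ccc(Cl)cc1`: 1000 nM
- Compound 2 `O=C(/C(=C\c1ccccc1OCc1ccccc1)Sc1ccc(F)cc1)c1ccc(Cl)cc1`: 1000 nM

In a functional assay on DU-145 cells (Homo sapiens) for inhibition, read by trypan blue exclusion, with a stated time of 96 h (a lower number here means a stronger inhibitor of growth, a higher number a weaker inhibitor of growth), compound 1 gives 1000 nM and compound 2 gives 1000 nM, so the two stand level. Compound 3 `COc1ccccc1/C=C(/SCc1ccc(F)cc1)C(=O)c1ccc(Cl)cc1` differs from compound 1 at another place, with benzyloxy cut back to methoxy: hydrogen in place of phenyl on a saturated chain carbon bound to an oxygen on an aromatic ring. For the measured compounds named here, the only measured step, no change at the digits printed from compound 1 to compound 2 (within the scatter), concerns the group on sulfur, so it offers only a loose guide and no direction for this change. A modest weakening in this assay is a tentative expectation, and the expected step is a 1.5-fold higher number from compound 1 to compound 3 (0.18 log units; within the scatter). For compound 3 the estimate is 1500 nM, with an expected range of 350 nM to 6500 nM.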

Compound 3, concentration for 50% growth inhibition: 10000 nM
The estimate for compound 3 lay 6.7-fold (0.82 log units) below the measured number; the whole stated range lies below it.
By their numbers in this assay, from the lowest: compounds 1 and 2 (each within the scatter of the next); then compound 3.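

In this assay cutting benzyloxy back to methoxy brings a 10-fold higher number from compound 1 to compound 3 (1.00 log units; beyond the scatter) and so this position, unlike the group on sulfur in the earlier pair, does move the read-out. The phenyl on this saturated chain carbon therefore counts for growth inhibition in these cells, though a single pair cannot say how. Nothing available accounts for this drop. Still open, as far as these compounds go, is whether the phenyl itself is needed, or whether a plain longer chain such as butoxy, or a cyclohexylmethoxy group, would serve equally well in the same place.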